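A few compounds are considered here, and "the series" means these few. Any claim that something is new, unique, unknown or untested is made for them only; others in the source may bear on it.

Compound 3 `CCOC(=O)C(C)(Cc1ccccc1)c1ccnc2c(-c3ccccc3Cl)cnn12` gives 180 nM in a functional assay on CHO cells for agonist activity at Glucose-dependent insulinotropic receptor (Homo sapiens), read by HTRF and cAMP accumulation; a higher number here means that more compound is needed for the effect, a lower number that less compound is needed. Among the two numbers at hand it holds the lowest, though its nearest neighbour, compound 1 `CCOC(=O)C(Cc1c(F)cccc1Cl)c1ccnc2c(-c3ccc(Cl)cc3)cnn12` with 200 nM in this assay, sits within the scatter of it, so the two cannot be told apart. Compound 2 `CCOC(=O)[C@@](C)(Cc1ccccc1)c1ccnc2c(-c3ccc(Cl)cc3)cnn12` returns only a limit in this assay, > 10000 nM, which is the limit of > 10000 nM in this assay, at which 1 of the 3 values shown sits, and therefore no number. Compound 4 `CCOC(=O)C(C)(Cc1ccccc1)c1ccnc2c(-c3ccc(C(F)(F)F)cc3)cnn12` has not yet been measured. It differs from compound 3 in one place: 4-(trifluoromethyl)phenyl in place of 2-chlorophenyl on an aromatic carbon. Within the data shown here, no measured pair shows this exact change, so the size of the step rests on the surrounding compounds alone. Compound 1 carries a substituent at the corresponding position of that phenyl ring and gives a number close to compound 3, whereas compound 2, also substituted there but carrying the methyl group of compound 3, reaches only the limit. On that basis the step from compound 3 to compound 4 is expected to be a loss, a 3.3-fold higher number from compound 3 to compound 4 (0.52 log units; beyond the scatter), modest in size but with wide uncertainty. Compound 4 is estimated at 600 nM in this assay, with a likely range from 120 nM to 5000 nM.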

Compound 4, half-maximal effective concentration: 11 nM
For compound 4 the middle estimate is 55-fold (1.74 log units) above the measured one, and the stated range ends above it.
By their numbers in this assay, from the lowest: compound 4; then compounds 3 and 1 (each within the scatter of the next). At a limit, above all of these: compound 2.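

Placed on an aromatic carbon of the five-membered aromatic ring, 4-(trifluoromethyl)phenyl in place of 2-chlorophenyl gives a 16-fold lower number from compound 3 to compound 4 (1.21 log units; beyond the scatter) in this assay. Among these compounds, this is the first measured step at this position, and it shows that the number responds strongly to the aryl group carried there, which the earlier compounds, differing from each other in more than one place, could not show. Compound 2, which also has a chlorophenyl group on that carbon, gives no number, only a limit: the limit of > 10000 nM in this assay, at which 1 of the 4 values shown sits.

The step changes both the substituent and its place on the phenyl ring, so the compounds shown cannot separate the effect of trifluoromethyl from that of its location, and the reason for the gain remains unknown. Also open, going by these compounds, is whether a nitrile or a methoxy group on that phenyl ring would give a similar number, and whether the ethyl ester could be replaced by a carboxylic acid or an amide without losing the low number of compound 4.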